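The source may report more compounds than this note shows. Statements on the series, on what has been measured and on what is new or still open speak of the compounds shown alone.

In a functional assay on MCF7 cells (Homo sapiens) for antiproliferative activity, read by MTT assay, with a stated time of 72 h (a higher number here means a weaker inhibitor, a lower number a stronger inhibitor), compound 1 `CCOc1ccc(-c2ccc3ncn(-c4cc(OC)c(OC)c(OC)c4)c3c2)cc1`, with 4-ethoxyphenyl on the shared core, gives 1710 nM. Compound 2 `COc1cc(-n2cnc3ccc(-c4ccccc4Cl)cc32)cc(OC)c1OC`, with 2-chlorophenyl in that place, reads > 10000 nM, which is a limit of the assay and not a number. Among the compounds with values here, compound 3 `COc1cc(-n2cnc3ccc(-c4cccc(O)c4)cc32)cc(OC)c1OC`, with 3-hydroxyphenyl, gives 350 nM, the lowest number so far.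

The next compound, compound 4 `COc1cc(-n2cnc3ccc(-c4cccc([N+](=O)[O-])c4)cc32)cc(OC)c1OC`, keeps the rest of compound 3 and carries nitro in place of hydroxy on an aromatic carbon. Within the data shown here, no measured step makes this exchange on its own. The closest evidence is the pair of steps leading to 3-hydroxyphenyl: a 4.9-fold lower number from compound 1 to compound 3 (0.69 log units; beyond the scatter) and an at least 28-fold lower number from compound 2 to compound 3 (1.45 log units; beyond the scatter). Both replace the whole substituted phenyl, so they show how far the number can travel at this place, but they do not isolate hydroxy. Among these three compounds, only compound 3 carries hydroxy, and neither of the others reaches its 350 nM. A step to a higher number in this assay, modest in size, is therefore expected, though with wide uncertainty.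

The expected step is a 3.4-fold higher number from compound 3 to compound 4 (0.54 log units; beyond the scatter).

Compound 4 is estimated at 1200 nM, with an expected range of 250 nM to 6000 nM.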

Compound 4, half-maximal inhibitory concentration: 4560 nM
For compound 4 the middle estimate is 3.8-fold (0.58 log units) below the measured one; the range from low to high includes it.
By their numbers in this assay, from the lowest: compound 3; then compound 1; then compound 4. At a limit, above all of these: compound 2.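

In this assay, the exchange of hydroxy for nitro isolates a single group on the 3-substituted phenyl, and it gives a 13-fold higher number from compound 3 to compound 4 (1.11 log units; beyond the scatter), so the low number of compound 3 depends on the group itself and not merely on having a substituent at this place. The 3-nitrophenyl group also gives a poorer reading than 4-ethoxyphenyl, with a 2.7-fold higher number from compound 1 to compound 4 (0.43 log units; beyond the scatter), so a phenyl substituted at this place does not by itself give a lower number than compound 1. The step of an at least 2.1-fold lower number from compound 2 to compound 4 (0.34 log units; beyond the scatter) is a minimum and not an exact size, since compound 2 sits at a limit of the assay: the limit of > 10000 nM in this assay, at which 1 of the 4 values shown sits.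

Hydroxy and nitro differ at once in heavy atoms, hydrogen-bond donors and hydrogen-bond acceptors, so this one pair does not show which of these differences goes with the step. On these data alone, whether an amine or a carboxylic acid in the place of hydroxy would read nearer to compound 3 or to compound 4 stays open.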